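This account rests on a few compounds, and the source may have more. Where it says the series, first, only, none or still open, it means among the compounds named here.

Among the compounds with values here, compound 2, `CC1=C(N2CC2)C(=O)C(C(C)COC(N)=O)=C(N2CC2)C1=O`, stands highest of the two numbers so far in a functional assay on L1210 cells (Mus musculus), with a stated time of 12 days (on this read-out lower numbers stand for lower potency and higher numbers for higher potency (the scale is a negative logarithm)), where compound 2 gives 5.71. Within the data shown here, its only neighbour is compound 1, `CCOC(COC(N)=O)C1=C(N2CC2)C(=O)C(C)=C(N2CC2)C1=O`, and in this assay compound 1 gives 5.22. Among the measured compounds shown here, the one measured step, a number 0.49 log units higher from compound 1 to compound 2 (beyond the scatter), comes from methyl in place of ethoxy on a saturated chain carbon bound to a double-bonded ring carbon and a saturated chain carbon.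

Compound 3, `CCC(COC(N)=O)C1=C(N2CC2)C(=O)C(C)=C(N2CC2)C1=O`, has not yet been measured. It differs from compound 2 by methyl in place of hydrogen on a saturated chain carbon, two bonds along the chain from a double-bonded ring carbon.

The measured step bears on this only loosely: it concerns a different group on a different saturated chain carbon, so it shows that changes along this chain can move this assay by a modest amount, but it does not show which way a methyl added further out would move it. Adding one carbon to the chain is therefore expected to give at most a small change, within the scatter, and compound 3 is estimated at 5.8, between 5.3 and 6.3, an expected step of a number 0.09 log units higher from compound 2 to compound 3 (within the scatter).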

Compound 3, logarithm of the reciprocal of the active concentration, log(1/C): 5.66
Estimate against measurement, compound 3: 0.14 log units above, within the range that was stated.
By their numbers in this assay, from the lowest: compound 1; then compounds 3 and 2 (each within the scatter of the next).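

Going from methyl to ethyl, on a saturated chain carbon two bonds along the chain from a double-bonded ring carbon, gives no readable change in this assay (a number 0.05 log units lower from compound 2 to compound 3 (within the scatter)), so compounds 2 and 3 cannot be told apart on this read-out and this added methyl neither gains nor costs measurable potency here. The comparison with the ethoxy compound is sharper: ethyl in place of ethoxy on the saturated chain carbon bound to the ring gives a step beyond the scatter (a number 0.44 log units higher from compound 1 to compound 3 (beyond the scatter)), close in size to the step already seen with methyl, so among these three compounds both groups made only of carbon and hydrogen stand above ethoxy, with no exception. Nothing measured here explains why these numbers fall as they do.

On these data alone, whether the flat reading from methyl to ethyl holds for a longer chain such as propyl or butyl on this carbon remains open. So does the reading for other groups there, such as methoxy, an amine or a carboxylic acid, which would show whether the lower number of compound 1 belongs to ethoxy alone.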